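This account rests on a few compounds, and the source may have more. Where it says the series, first, only, none or still open, it means among the compounds named here.

Measured in a functional assay on Bel-7402 cells (Homo sapiens) for antiproliferative activity, with a stated time of 72 h; on this read-out lower numbers stand for stronger inhibition and higher numbers for weaker inhibition:
- compound 1 `COC(=O)CN(C)Cc1c(OC)cc(OC)c(C(=O)/C=C/c2ccccc2Cl)c1O`: 8500 nM
- compound 2 `COc1cc(OC)c(C(=O)/C=C/c2ccccc2Cl)c(O)c1CN1CCCC1`: 6800 nM
- compound 3 `COc1cc(OC)c(C(=O)/C=C/c2ccccc2Cl)c(O)c1CN1CCCCC1`: 3100 nM

Compound 3 has the lowest number of the three, and its steps to both others lie beyond the scatter. The next structure is compound 4 `COc1cc(OC)c(C(=O)/C=C/c2ccccc2Cl)c(O)c1CN(C)CC(=O)O`, which differs from compound 3 as follows: (carboxymethyl)(methyl)amino in place of piperidin-1-yl on a saturated chain carbon bound to an aromatic carbon. In words, this places (carboxymethyl)(methyl)amino in place of piperidin-1-yl on a saturated chain carbon bound to an aromatic carbon.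

Among the measured compounds shown here, no measured compound carries the (carboxymethyl)(methyl)amino group. The nearest measured group is the ((methoxycarbonyl)methyl)(methyl)amino of compound 1, so the most relevant comparison is a 2.7-fold lower number from compound 1 to compound 3 (0.44 log units; beyond the scatter). Two further steps show how much the amine alone moved the number: a 1.3-fold lower number from compound 1 to compound 2 (0.10 log units; within the scatter) and a 2.2-fold lower number from compound 2 to compound 3 (0.34 log units; beyond the scatter). All three steps are small, and the data do not show how the free carboxymethyl group compares with its methyl ester.

Reversing the direction of the step to compound 3 from compound 1 a 2.7-fold lower number from compound 1 to compound 3 (0.44 log units; beyond the scatter), a rise in the number is expected. The expected step is a 3.5-fold higher number from compound 3 to compound 4 (0.55 log units; beyond the scatter). For compound 4 the estimated value is 11000 nM, with an expected range of 5000 nM to 30000 nM.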

Compound 4, half-maximal inhibitory concentration: 35200 nM
For compound 4 the middle estimate is 3.2-fold (0.51 log units) below the measured one; measured number above the stated range.
By their numbers in this assay, from the lowest: compound 3; then compounds 2 and 1 (each within the scatter of the next); then compound 4.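

In this assay the (carboxymethyl)(methyl)amino group gives the largest change yet seen on this saturated chain carbon, with an 11-fold higher number from compound 3 to compound 4 (1.06 log units; beyond the scatter) and with a 5.2-fold higher number from compound 2 to compound 4 (0.71 log units; beyond the scatter) against the pyrrolidin-1-yl amine. The ester and the free acid can now be read directly, and replacing methyl with hydrogen on the oxygen next to the carbonyl group gives a 4.1-fold higher number from compound 1 to compound 4 (0.62 log units; beyond the scatter) in a pair that differs in that one place only. Compound 4 therefore has the highest number of the four, with its steps to all three others beyond the scatter, so this position tolerates the cyclic amines and the methyl ester better than the free acid in this cell assay.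

Open, going by these compounds, is whether an amide of the carboxymethyl group or a carboxyethyl chain would stay nearer compound 1 or nearer compound 4, and whether a morpholin-4-yl or azepan-1-yl ring would lower the number beyond that of compound 3. Nothing available bears on why the free acid gives the higher number.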